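The source may hold more compounds than are shown below. What is called first, only, known or untested is meant among the compounds shown, and "the series" means these compounds.

Working notes on the series. Compound 1 `O=C(O)c1ccc(CN2C(=O)S/C(=C\c3cccnc3)C2=O)cc1` gives 75000 nM in a functional assay on A549 cells (Homo sapiens) for cytotoxicity, read by MTT assay, with a stated time of 24 h; on this read-out higher numbers stand for weaker inhibition and lower numbers for stronger inhibition. Compound 2 `O=C(O)c1ccc(CN2C(=O)S/C(=C\c3ccccc3)C2=O)cc1` gives 90000 nM and compound 3 `O=C(O)c1ccc(CN2C(=O)S/C(=C\c3ccccn3)C2=O)cc1` gives 80000 nM in this assay. Compound 1 has the lowest of the three numbers, yet every step among them is within the scatter: a 1.2-fold higher number from compound 1 to compound 2 (0.08 log units; within the scatter), a 1.1-fold higher number from compound 1 to compound 3 (0.03 log units; within the scatter) and a 1.1-fold lower number from compound 2 to compound 3 (0.05 log units; within the scatter). The three aromatic groups on the double-bonded chain carbon are thus not told apart by this test.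

Compound 4 `Cc1ccc(/C=C2\SC(=O)N(Cc3ccc(C(=O)O)cc3)C2=O)cc1` differs from compound 1 in one place: 4-methylphenyl in place of pyridin-3-yl on a double-bonded chain carbon bound to a double-bonded ring carbon. The closest measured step is the one with phenyl in place of pyridin-3-yl, a 1.2-fold higher number from compound 1 to compound 2 (0.08 log units; within the scatter), which stayed within the scatter. No step beyond the scatter is therefore expected in this assay for compound 4. Compound 4 is estimated at 80000 nM, with a range of 40000 nM to 160000 nM. The expected step is a 1.1-fold higher number from compound 1 to compound 4 (0.03 log units; within the scatter).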

Compound 4, half-maximal inhibitory concentration: 78000 nM
Compound 4: the middle estimate sits 1.0-fold (0.01 log units) above what was measured, within the range that was stated.
By their numbers in this assay, from the lowest: compounds 1, 4, 3 and 2 (each within the scatter of the next).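

The steps from pyridin-3-yl (a 1.0-fold higher number from compound 1 to compound 4 (0.02 log units; within the scatter)) and pyridin-2-yl (a 1.0-fold lower number from compound 3 to compound 4 (0.01 log units; within the scatter)) to 4-methylphenyl stay within the scatter in this assay. Methyl in place of hydrogen on an aromatic carbon (a 1.2-fold lower number from compound 2 to compound 4 (0.06 log units; within the scatter)) is the first substituent seen on this aromatic group, and it also leaves the compounds unseparated. No supporting data bear on this flat reading.

From the compounds shown here alone, whether an amine or a longer chain on this aromatic group would give a step beyond the scatter stays open. Also open, going by these compounds, is whether any change elsewhere on the shared core moves the number.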